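This account rests on a few compounds, and the source may have more. Where it says the series, first, only, none or still open, it means among the compounds named here.

Compound 1 `N#Cc1c(Nc2ccc(O)cc2)sc2ccccc12` is the reference point here. Within the data shown here, in a functional assay on HUVEC cells (Homo sapiens), read by fluorescence and microscopy, with a stated time of 6 h, tested at 10 uM (on this read-out lower numbers stand for a stronger effect and higher numbers for a weaker effect at the one concentration tested), compound 1 gives 25%, the lowest of the three numbers measured so far. Compound 2 `CC(=O)N(c1ccc(O)cc1)c1sc2ccccc2c1C#N` gives 36%, and compound 3 `COc1cc2sc(Nc3ccccc3)c(C#N)c2cc1OC` gives 77%, the furthest from compound 1. Among the measured compounds shown here, the one measured step between neighbours, a number 11 percentage points higher from compound 1 to compound 2 (beyond the scatter), comes from putting acetyl in place of hydrogen on a nitrogen on an aromatic ring.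

Compound 4 `N#Cc1c(Nc2ccc(C(F)(F)F)cc2)sc2ccccc12` is not yet measured. It differs from compound 1 in one place: trifluoromethyl in place of hydroxy on an aromatic carbon

For the measured compounds named here, no measured step changes a group on this aromatic carbon, so the step from compound 1 to compound 2 bears on the new change only loosely, showing that a single exchange on the shared core can move the number by a modest amount. Because the measured change in a number 11 percentage points higher from compound 1 to compound 2 (beyond the scatter) weakened the effect, a shift of similar size or somewhat larger, towards a weaker effect, is expected for compound 4, with wide uncertainty. For compound 4 the estimate is 45%, between 20% and 75%, meaning an expected step of a number 20 percentage points higher from compound 1 to compound 4 (beyond the scatter).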

Compound 4, a percentage reported as activity, at one concentration (the size of the read-out at that concentration, not a potency): 24%
Compound 4: middle estimate off by 21 percentage points, on the high side; the measured number falls inside the stated range.
By their numbers in this assay, from the lowest: compounds 4 and 1 (each within the scatter of the next); then compound 2; then compound 3.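

Placing trifluoromethyl where compound 1 carries hydroxy gives a number 1 percentage points lower from compound 1 to compound 4 (within the scatter) in this assay on this aromatic carbon. At the one concentration tested, the hydroxy group is therefore not required here for the effect seen, and its hydrogen-bond donor and acceptor can both be lost without a change beyond the scatter. The entering group also has more heavy atoms, so this position accepts at least this larger group, but nothing measured here explains why the two compounds read alike.

From the compounds shown here alone, whether an amine, a carboxylic acid or a longer chain such as butoxy on this carbon would also leave the number in place remains open. A single concentration also leaves open whether the two compounds would match across a range of concentrations.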